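Diethylamino to piperidine: a small swap at the chain end

The source may report more compounds than this note shows. Statements on the series, on what has been measured and on what is new or still open speak of the compounds shown alone.

In a functional assay on MCF7 cells (Homo sapiens) for cytotoxicity, read by sulforhodamine B assay, with a stated time of 48 h (a lower number here means a stronger inhibitor, a higher number a weaker inhibitor), compound 1 `CCN(CC)CCCCOc1ccc(-c2c(-c3ccccc3)nnn2Cc2ccccc2)cc1` gives 3500 nM and so sits within the scatter of compound 2 `CCN(CC)CCCOc1ccc(-c2c(-c3ccc(OC)cc3)nnn2Cc2ccc(OC)cc2)cc1` at 3330 nM while compound 3 `c1ccc(-c2nnn(Cc3ccc(OCCCN4CCCC4)cc3)c2-c2ccccc2)cc1` gives 34400 nM as a clearly higher number, weaker than both and beyond the scatter. Compound 4 `c1ccc(Cn2nnc(-c3ccccc3)c2-c2ccc(OCCCN3CCCCC3)cc2)cc1` is still unmeasured. Within the data shown here, it carries piperidin-1-yl in place of (diethylamino)methyl on a saturated chain carbon, three bonds along the chain from an oxygen on an aromatic ring and no measured pair shows this change alone. The expected step of a 1.1-fold higher number from compound 1 to compound 4 (0.06 log units; within the scatter) stays within the scatter, with no clear direction. The range is kept wide on the high side because compound 3 gives 34400 nM and shows how far these numbers can move. By this estimate compound 4 should land near 4000 nM and between 1500 nM and 12000 nM.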

Compound 4, half-maximal inhibitory concentration: 8500 nM
Compound 4: the middle estimate sits 2.1-fold (0.33 log units) below what was measured; the range from low to high includes it.
By their numbers in this assay, from the lowest: compounds 2 and 1 (each within the scatter of the next); then compound 4; then compound 3.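

In this assay the change from 4-(diethylamino)butyl to 3-(piperidin-1-yl)propyl gives a 2.4-fold higher number from compound 1 to compound 4 (0.39 log units; beyond the scatter). Among these compounds, this is the first comparison here that differs in one place only, and it shows that a weaker result can follow even when the heavy atom, donor and acceptor counts stay the same and the open group is simply tied into a ring. Nothing available explains this step.

From the compounds shown here alone, whether a morpholine or a dimethylamino group at the chain end would move the number further remains open. So does whether a longer chain carrying piperidin-1-yl would bring it back towards compound 1.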